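Working notes: from cyclopropyl to cyclohexyl

The source may hold more compounds than are shown below. What is called first, only, known or untested is meant among the compounds shown, and "the series" means these compounds.

Measured in an ADME assay on a cell-free system (plasma, Homo sapiens); on this read-out lower numbers stand for a smaller free fraction and higher numbers for a larger free fraction:
- compound 1 `CCNC(=O)Nc1nc2cc(-c3ccc(F)nc3)c(=O)n(C)c2s1`: "not determined" (no result reported)
- compound 2 `CCNC(=O)Nc1nc2cc(-c3cccnc3)c(=O)n(CC3CC3)c2s1`: 0.05
- compound 3 `C=CCNC(=O)Nc1nc2cc(-c3cccnc3)c(=O)n(CCC(C)C)c2s1`: 0.03

Compound 2 and compound 3 lie within the scatter of each other, and compound 1 adds no number. Compound 4 `CCNC(=O)Nc1nc2cc(-c3cccnc3)c(=O)n(CC3CCCCC3)c2s1` carries cyclohexyl in place of cyclopropyl on a saturated chain carbon bound to an aromatic nitrogen. Going by the values given here, no measured pair differing in one place shows this change, so support is thin. In this assay, a modest downward step is expected, with compound 3 at 0.03 as the only nearby reference. The estimated step of a 2.5-fold lower number from compound 2 to compound 4 (0.40 log units; beyond the scatter) is small. Compound 4 is estimated at 0.02, with an expected range of 0.008 to 0.04.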

Compound 4, unbound fraction: 0.02
For compound 4 middle estimate and measured number coincide at the digits printed; measured number inside the range.
By their numbers in this assay, from the lowest: compounds 4, 3 and 2 (each within the scatter of the next, the first and the last beyond it).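

In this assay this saturated chain carbon bound to an aromatic nitrogen now has its first single-place comparison: cyclohexyl in place of cyclopropyl gives a 2.5-fold lower number from compound 2 to compound 4 (0.40 log units; beyond the scatter), a step beyond the scatter. The position therefore responds to this exchange of rings, although one pair establishes no trend. Nothing measured here bears on the origin of the step.

Still open, from the compounds shown here alone, is whether cyclobutyl or cyclopentyl would fall along the same line. Also open, going by these compounds, is how a ring carrying an amine or a carboxylic acid would read at this position.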